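Ethyl in place of 2-hydroxycyclohexyl on the shared core

The compounds below may be only part of what the source reports. "The series", "measured", "known", "first", "only" and "open" are said of these compounds alone.

This account follows a single change on the nitrogen of an aromatic ring in a small set of compounds sharing one core. Compound 1 `CCCCCCNc1nc(-c2ccccc2)nc2c1nnn2Cc1ccccc1` gives 13200000 nM in an assay on isolated protein for binding affinity to adenosine receptor A1 (Bos taurus); on this read-out higher numbers stand for weaker inhibition and lower numbers for stronger inhibition. Compound 2 `O[C@H]1CCCC[C@@H]1Nc1nc(-c2ccccc2)nc2c1nnn2Cc1ccccc1` gives 10300000 nM in this assay, while compound 3 `FC(F)(F)c1ccccc1Cn1nnc2c(NC3CCCC3)nc(-c3ccccc3)nc21` gives 600000 nM. Among the three numbers, compound 2 stands second highest; its nearest neighbour is compound 1, and the step of a 1.3-fold lower number from compound 1 to compound 2 (0.11 log units; within the scatter) is within the scatter. Compound 3 differs from compound 2 in two places at once, so its much lower number cannot be tied to either change alone.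

The unmeasured compound 4 `CCNc1nc(-c2ccccc2)nc2c1nnn2Cc1ccccc1` differs from compound 2 as follows: ethyl in place of 2-hydroxycyclohexyl on a nitrogen on an aromatic ring. Going by the values given here, the only measured step that bears on this position is the exchange of hexyl for 2-hydroxycyclohexyl from compound 1 to compound 2, which lay within the scatter. Nothing here shows that a group on this nitrogen moves the number beyond the scatter, so the step of a 1.5-fold higher number from compound 2 to compound 4 (0.16 log units; within the scatter) is expected to be small in either direction. Compound 4 is therefore estimated at 15000000 nM in this assay, with a range from 4000000 nM to 60000000 nM.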

Compound 4, inhibition constant: 91000000 nM
The estimate for compound 4 lay 6.1-fold (0.78 log units) below the measured number; measured number outside the range, above it.
By their numbers in this assay, from the lowest: compound 3; then compounds 2 and 1 (each within the scatter of the next); then compound 4.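

In this assay the group on this nitrogen proves able to move the number beyond the scatter, something the exchange of hexyl for 2-hydroxycyclohexyl could not show: the change to ethyl gives an 8.8-fold higher number from compound 2 to compound 4 (0.95 log units; beyond the scatter) and the shortening of the hexyl chain gives a 6.9-fold higher number from compound 1 to compound 4 (0.84 log units; beyond the scatter) on the same shared core. Hexyl and 2-hydroxycyclohexyl, an open chain and a hydroxyl-bearing ring, stay within the scatter of each other, so among these three groups neither the ring nor the hydroxyl is needed for the lower numbers, and only ethyl, the group with the fewest heavy atoms here, stands apart. No independent evidence bears on why the shorter group gives the higher number.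

The compounds shown leave open whether a propyl or butyl chain on this nitrogen would stay near compound 1 or near compound 4, and so where along the chain the step arises. They also leave open what an unsubstituted cyclohexyl would give, and compound 3 cannot settle this, as it differs from the others in two places.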